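The source may hold more compounds than are shown below. What is called first, only, known or untested is meant among the compounds shown, and "the series" means these compounds.

In an assay on CHO cells for displacement of a labelled ligand from muscarinic acetylcholine receptor M5 (Homo sapiens), read by scintillation counting, with a stated time of 2 h (a lower number here means a stronger inhibitor, a higher number a weaker inhibitor), compound 1 `O=C(OCCc1ccc(Cl)c(Cl)c1)N(c1ccccc1)C1CN2CCC1CC2` gives 80 nM, compound 2 `COc1ccc(COC(=O)N(c2ccccc2)C2CN3CCC2CC3)cc1OC` gives 550 nM, and compound 3 `COc1ccc(CCCOC(=O)N(c2ccccc2)C2CN3CCC2CC3)cc1F` gives 260 nM. Compound 3 thus stands second highest of the three, close to compound 2 and furthest from compound 1. Compound 4 `O=C(OCCCc1ccccc1)N(c1ccccc1)C1CN2CCC1CC2` differs from compound 3 by phenyl in place of 3-fluoro-4-methoxyphenyl on a saturated chain carbon, three bonds along the chain from an oxygen next to a carbonyl group, so the two substituents on the outer ring fall away while the chain is kept. Among the compounds with values here, the one step measured at this part of the molecule, a 3.3-fold higher number from compound 1 to compound 3 (0.51 log units; beyond the scatter), changed the outer ring and its chain together, so it bears on the change only loosely. A step of modest size is expected, more likely upward, written as a 1.5-fold higher number from compound 3 to compound 4 (0.19 log units; within the scatter). For compound 4 the expected value in this assay is 400 nM, within a range of 150 nM to 1100 nM.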

Compound 4, inhibition constant: 260 nM
For compound 4 the middle estimate is 1.5-fold (0.19 log units) above the measured one; the range from low to high includes it.
By their numbers in this assay, from the lowest: compound 1; then compounds 3 and 4 (each within the scatter of the next); then compound 2.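

In this assay, stripping the fluorine and the methoxy group from the outer ring leaves the number unmoved, no change at the digits printed from compound 3 to compound 4 (within the scatter), so at this place 3-fluoro-4-methoxyphenyl and plain phenyl cannot be told apart. The gap to the dichloro compound therefore survives with a bare ring, a 3.3-fold higher number from compound 1 to compound 4 (0.51 log units; beyond the scatter), though that step changes the ring and its chain together. No measurement here gives a reason for either result. Still open, from the compounds shown here alone, is whether the chlorines or the chain length carries that gap, and whether an amine or a carboxylic acid on the outer ring would shift the number.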